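The source may report more compounds than this note shows. Statements on the series, on what has been measured and on what is new or still open speak of the compounds shown alone.

Measured so far in a functional assay on MIA PaCa-2 cells (Homo sapiens) for inhibition, read by MTT assay, with a stated time of 3 days; on this read-out lower numbers stand for stronger inhibition and higher numbers for weaker inhibition:
compound 1 `CCN(CC)S(=O)(=O)c1ccc(S(=O)(=O)N2CCC[C@@H](C(=O)N3CCC(O)CC3)C2)cc1`: 230 nM
compound 2 `CCN(CC)S(=O)(=O)c1ccc(S(=O)(=O)N2CCC[C@@H](C(=O)N3CCC(C(F)(F)F)CC3)C2)cc1`: 110 nM
compound 3 `CCN(CC)S(=O)(=O)c1ccc(S(=O)(=O)N2CCC[C@@H](C(=O)N[C@H]3CC[C@@H](OC)CC3)C2)cc1`: 590 nM

Compound 3 gives the highest number of the three, that is the weakest inhibition: the steps of a 2.6-fold higher number from compound 1 to compound 3 (0.41 log units; beyond the scatter) and a 5.4-fold higher number from compound 2 to compound 3 (0.73 log units; beyond the scatter) both lie beyond the scatter, so compound 3 is clearly the least active of the measured set.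

Compound 4 `CCN(CC)S(=O)(=O)c1ccc(S(=O)(=O)N2CCC[C@@H](C(=O)N3CCC(C(F)F)CC3)C2)cc1` is the next compound to be tested. It differs from compound 3 by 4-(difluoromethyl)piperidin-1-yl in place of (4-methoxycyclohexyl)amino on a carbonyl carbon. The two steps just named bear directly on this change, since each of them goes from a piperidin-1-yl group on the carbonyl carbon to the (4-methoxycyclohexyl)amino group and each raises the number; run backwards, they point to a lower number for compound 4. The step of a 2.1-fold lower number from compound 1 to compound 2 (0.32 log units; beyond the scatter) shows that the group on the piperidine ring shifts the number only modestly. Compound 4 is therefore expected to land close to compounds 1 and 2, with an estimated 150 nM, in a range from 60 nM to 400 nM. The expected step is a 3.9-fold lower number from compound 3 to compound 4 (0.59 log units; beyond the scatter).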

Compound 4, half-maximal inhibitory concentration: 140 nM
For compound 4 the middle estimate is 1.1-fold (0.03 log units) above the measured one; measured number inside the range.
By their numbers in this assay, from the lowest: compounds 2, 4 and 1 (each within the scatter of the next, the first and the last beyond it); then compound 3.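

In this assay, putting 4-(difluoromethyl)piperidin-1-yl in place of (4-methoxycyclohexyl)amino gives a 4.2-fold lower number from compound 3 to compound 4 (0.62 log units; beyond the scatter), so all three piperidin-1-yl groups on this carbonyl carbon now give lower numbers than the (4-methoxycyclohexyl)amino group, and no compound shown goes against this. On the piperidine ring, the steps of a 1.3-fold higher number from compound 2 to compound 4 (0.10 log units; within the scatter) and a 1.6-fold lower number from compound 1 to compound 4 (0.22 log units; within the scatter) both stay within the scatter, so difluoromethyl cannot be told apart from trifluoromethyl or from hydroxy, even though those two groups differ by a step beyond it. No supporting data explain these differences.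

Still open, from the compounds shown here alone, is whether the gap to compound 3 follows from the ring itself or from its methoxy group, which a 4-methoxypiperidin-1-yl group on the same carbonyl carbon would help separate. Going by these compounds, how a basic amine or a carboxylic acid on the piperidine ring would read out also remains unknown.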